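Urea aryl variation on the shared core: working notes

The source may report more compounds than this note shows. Statements on the series, on what has been measured and on what is new or still open speak of the compounds shown alone.

Measured so far:
compound 1 `O=C(Nc1cccc(-n2cc(-c3ccncc3)c(-c3cc(O)cc(Cl)c3)n2)c1)Nc1ccc(Cl)c(Cl)c1`: 1740 nM
compound 2 `COc1cc(Cl)cc(-c2nn(-c3cccc(NC(=O)Nc4cc(C(F)(F)F)cc(C(F)(F)F)c4)c3)cc2-c2ccncc2)c1`: 330 nM

In a functional assay on HCT-116 cells (Homo sapiens) for inhibition, read by sulforhodamine B assay, with a stated time of 48 h (a higher number here means a weaker inhibitor, a lower number a stronger inhibitor), compound 1 gives 1740 nM, and compound 2 gives 330 nM. Compound 2 holds the lower of the two numbers, and its gap to compound 1 is beyond the usual scatter, so compound 2 is the stronger inhibitor of the pair. The two compounds differ in several places at once, so the values show only the overall difference and not which change carries it.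

Compound 3 `COc1cc(Cl)cc(-c2nn(-c3cccc(NC(=O)Nc4cccc(C(F)(F)F)c4)c3)cc2-c2ccncc2)c1` keeps the shared core of compound 2 and alters only the urea aryl: hydrogen in place of trifluoromethyl on an aromatic carbon. Among the compounds with values here, no measured pair differs in this single place, so the step has no direct precedent here. Since the remaining trifluoromethyl is retained and the rest of compound 2 is unchanged, the expected step of a 2.1-fold higher number from compound 2 to compound 3 (0.33 log units; beyond the scatter) is a small loss in this assay, possibly no larger than the scatter. Compound 3 is estimated at 700 nM, with a range of 250 nM to 2000 nM.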

Compound 3, half-maximal inhibitory concentration: 750 nM
For compound 3 the middle estimate is 1.1-fold (0.03 log units) below the measured one; the range from low to high includes it.
By their numbers in this assay, from the lowest: compound 2; then compound 3; then compound 1.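

Hydrogen in place of trifluoromethyl on an aromatic carbon of the urea aryl gives a 2.3-fold higher number from compound 2 to compound 3 (0.36 log units; beyond the scatter) in this assay. This is the first reading of a single change in the series: with everything else held fixed, this position is shown not to be indifferent to its substituent, although the step is modest and compound 3 , which retains the other trifluoromethyl group, still gives 750 nM in this assay. Nothing measured alongside these values bears on why the number rises with this change.

The compounds shown leave open whether the loss is specific to trifluoromethyl or would also appear with another group on this carbon, such as a chlorine, a methoxy group, an amine or a carboxylic acid, and what removing the remaining trifluoromethyl group would do. Compound 1 differs from compound 2 and compound 3 in several places, so the separate contributions of its urea aryl and of the hydroxy group in place of methoxy on the other aryl ring remain unresolved.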